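Adding a 2-hydroxyethoxy group to compound 2

The source may report more compounds than this note shows. Statements on the series, on what has been measured and on what is new or still open speak of the compounds shown alone.

Compound 1 `N#Cc1ncc2nc1OC/C=C\COc1ccc(Cl)cc1NC(=O)N2`: > 10000 nM
Compound 2 `N#Cc1ncc2nc1OCC/C=C\COc1ccccc1NC(=O)N2`: > 10000 nM

Among the compounds with values here, the only measurements so far come from a functional assay on NCI-H1299 cells (Homo sapiens), read by flow cytometry; on this read-out lower numbers stand for an effect already at smaller amounts and higher numbers for an effect only at larger amounts of compound. Compound 2 gives > 10000 nM there, which is a limit of the assay and not a number. The same holds across the pair, with the limit of > 10000 nM in this assay, at which 2 of the 2 values shown sit. Within the data shown here, neither compound therefore has an exact value, and no measured step shows how a change to the structure moves the read-out.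

Compound 3 `N#Cc1ncc2nc1OCC/C=C\COc1ccc(OCCO)cc1NC(=O)N2` has 2-hydroxyethoxy in place of hydrogen on an aromatic carbon.

Any measurable value would have to fall on the lower side of the limit, so a modest gain is the expectation, though another limit is about as likely. The expected change is an at least 3.3-fold lower number from compound 2 to compound 3 (0.52 log units; beyond the scatter), and this size is only a rough estimate. Compound 3 is estimated at 3000 nM, with an expected range from 700 nM to 10000 nM.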

Compound 3, half-maximal effective concentration: > 10000 nM
Compound 3 was reported as a limit; the forecaster's own chance of this, stated with the estimate: 50%; at least 3.3-fold (0.52 log units) between middle value and limit.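

In this assay compound 3 gives > 10000 nM, which is a limit and not a number. Within the data shown here, compound 2 also stands at a limit there, and no step from compound 2 to compound 3 can be read. The compounds shown leave open whether 2-hydroxyethoxy in place of hydrogen moves the read-out at all.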